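A Pyrazinyl Sulfone in Place of a Fluorophenyl Sulfone

The source may hold more compounds than are shown below. What is called first, only, known or untested is meant among the compounds shown, and "the series" means these compounds.

Measured so far in a functional assay (Cavia porcellus) with sulfonylurea receptors; K-ATP channels (Homo sapiens) as the target; a lower number here means a stronger inhibitor, a higher number a weaker inhibitor:
compound 1, `CC(O)(C(=O)Nc1ccc(S(=O)(=O)c2cccc(F)c2)cc1)C(F)(F)F`: 3400 nM
compound 2, `CC(O)(C(=O)Nc1ccc([N+](=O)[O-])c(S(=O)(=O)c2ccccc2)c1)C(F)(F)F`: > 30000 nM

Among the measured compounds shown here, compound 1 stands as the only compound of the two with an actual number in this assay. The value of compound 2 is a limit of the assay and not a number, namely (the limit of > 30000 nM in this assay, at which 1 of the 2 values shown sits).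

Compound 3, `CC(O)(C(=O)Nc1ccc(S(=O)(=O)c2cnccn2)cc1)C(F)(F)F`, differs from compound 1 by pyrazin-2-yl in place of 3-fluorophenyl on a sulfonyl sulfur. For the measured compounds named here, no step between measured compounds is available, so the size of this change must be judged from compound 1 alone. A modest loss of inhibitory strength is expected, a 2.4-fold higher number from compound 1 to compound 3 (0.37 log units; beyond the scatter). Compound 3 is therefore estimated at 8000 nM, with a range from 2000 nM to 30000 nM.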

Compound 3, half-maximal inhibitory concentration: 12000 nM
Compound 3: middle estimate off by 1.5-fold (0.18 log units), on the low side; measured number inside the range.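

In this assay, pyrazin-2-yl in place of 3-fluorophenyl on a sulfonyl sulfur gives a 3.5-fold higher number from compound 1 to compound 3 (0.55 log units; beyond the scatter), a modest loss of inhibitory strength. As the first step read at this position, it shows that this aromatic ring can take two ring nitrogens and lose its fluorine while the inhibition remains measurable. Nothing measured here accounts for the size of this step.

The compounds shown leave open whether the ring nitrogens or the missing fluorine carries the step. On these data alone, how a pyridin-2-yl or a 3-chlorophenyl on the same sulfur would stand also remains open.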